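Shortening the Amide Tail of a Vitamin D Receptor Ligand

The source may hold more compounds than are shown below. What is called first, only, known or untested is meant among the compounds shown, and "the series" means these compounds.

Measured compounds:
compound 1 `CCn1c(C(=O)NCCCN(C)C)ccc1C(CC)(CC)c1ccc(OCC(O)C(C)(C)C)c(C)c1`: 197 nM
compound 2 `CCN(CC)CCCNC(=O)c1ccc(C(CC)(CC)c2ccc(OCC(O)C(C)(C)C)c(C)c2)n1CC`: 71.1 nM

In an assay on isolated protein for binding affinity to vitamin D3 receptor (Homo sapiens), with a stated time of 4 h (on this read-out higher numbers stand for weaker inhibition and lower numbers for stronger inhibition), compound 1 gives 197 nM and compound 2 gives 71.1 nM. For the measured compounds named here, compound 2 holds the lowest of the two numbers, and the only measured step, a 2.8-fold lower number from compound 1 to compound 2 (0.44 log units; beyond the scatter), separates it from compound 1. Compound 3 `C#CCNC(=O)c1ccc(C(CC)(CC)c2ccc(OCC(O)C(C)(C)C)c(C)c2)n1CC` has not been measured in this assay. It differs from compound 2 by ethynyl in place of 2-(diethylamino)ethyl on a saturated chain carbon bound to an amide-type nitrogen. The measured step bears on this change only indirectly: it concerned a small enlargement of the amine at the end of the chain, whereas compound 3 removes the amine-bearing part of the chain altogether and leaves a much shorter group on the amide nitrogen. Going by the values given here, no measured pair shows what such a removal does. Because a 2.8-fold lower number from compound 1 to compound 2 (0.44 log units; beyond the scatter) showed that changes at this tail shift the number, compound 3 is expected to move as well, most likely toward a higher number, with wide uncertainty. The step from compound 2 is estimated as a 2.5-fold higher number from compound 2 to compound 3 (0.40 log units; beyond the scatter). Compound 3 is therefore expected to give about 180 nM in this assay, within a range of 45 nM to 700 nM.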

Compound 3, half-maximal inhibitory concentration: > 10000 nM
Compound 3: no number, only a limit; the forecaster's own chance of this, stated with the estimate: 10%; middle value at least 55-fold (1.74 log units) away from the limit.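

In this assay compound 3 gives > 10000 nM, which is a limit of the assay and not a number. Replacing 3-(diethylamino)propyl with propargyl on the amide-type nitrogen gives an at least 140-fold higher number from compound 2 to compound 3 (2.14 log units; beyond the scatter), and the matching change from the dimethylamino chain gives an at least 50-fold higher number from compound 1 to compound 3 (1.70 log units; beyond the scatter). Both are far larger than the earlier change at the end of the chain, a 2.8-fold lower number from compound 1 to compound 2 (0.44 log units; beyond the scatter), so this tail can go from adjusting the number modestly to taking it out of the measured range. These two steps give only minimum sizes, because the reading for compound 3 is not an exact number: the limit of > 10000 nM in this assay, at which 1 of the 3 values shown sits.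

Compound 3 shortens the chain and removes the amine in a single change, and the compounds shown cannot separate those two effects or say which one matters. A plain alkyl chain with no amine, or a hydroxyl group in place of the amine at the chain end, would be needed to tell whether the amine itself or the length of the chain goes with the lower numbers.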